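Replacing the ethoxy group of compound 3

The source may report more compounds than this note shows. Statements on the series, on what has been measured and on what is new or still open speak of the compounds shown alone.

In a functional assay for inhibition, with Homo sapiens as the target (a lower number here means a stronger inhibitor, a higher number a weaker inhibitor), compound 1 `COc1ccc(-c2nc(-c3ccc4c(c3)CCC(=O)N4)cs2)cc1OC` gives 300 nM, compound 2 `COc1cc(-c2nc(-c3ccc4c(c3)CCC(=O)N4)cs2)ccc1SC` gives 400 nM and compound 3 `CCOc1ccc(-c2nc(-c3ccc4c(c3)CCC(=O)N4)cs2)cc1OC` gives 600 nM, which places compound 3 within the scatter of both others. Compound 4 `COc1cc(-c2nc(-c3ccc4c(c3)CCC(=O)N4)cs2)ccc1[S+](C)[O-]` exchanges the ethoxy of compound 3 for a sulfur-bearing group: a group of 3 heavy atoms (1 carbon, 1 oxygen, 1 sulfur; no ring) in place of a group of 3 heavy atoms (2 carbon, 1 oxygen; no ring), on an aromatic carbon. The closest evidence is a 1.5-fold higher number from compound 2 to compound 3 (0.18 log units; within the scatter), with ethoxy in place of methylsulfanyl, and a 1.3-fold higher number from compound 1 to compound 2 (0.12 log units; within the scatter), with methylsulfanyl in place of methoxy. The step of a 2.0-fold higher number from compound 1 to compound 3 (0.30 log units; within the scatter) also stays within the scatter. None of these compounds carries the entering group itself, so the evidence is indirect. No move beyond the scatter is expected, and the estimated step is a 1.3-fold higher number from compound 3 to compound 4 (0.12 log units; within the scatter). Compound 4 is expected at 800 nM, within an estimated range of 250 nM to 2500 nM.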

Compound 4, half-maximal inhibitory concentration: 800 nM
Compound 4: middle estimate and measured number agree at the digits printed; the range from low to high includes it.
By their numbers in this assay, from the lowest: compounds 1, 2, 3 and 4 (each within the scatter of the next, the first and the last beyond it).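

In this assay the entering group, on an aromatic carbon para to a large group, gives a 1.3-fold higher number from compound 3 to compound 4 (0.12 log units; within the scatter) and a 2.0-fold higher number from compound 2 to compound 4 (0.30 log units; within the scatter) and so cannot be told apart from ethoxy or methylsulfanyl at this position. Against methoxy it gives a 2.7-fold higher number from compound 1 to compound 4 (0.43 log units; beyond the scatter) as the first step in this set beyond the scatter, though a modest one. Nothing at hand accounts for this result.

The compounds shown leave open how an amine, a carboxylic acid or a longer chain would read at this position. They also leave open whether methylsulfonyl would follow the entering group.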